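The source may report more compounds than this note shows. Statements on the series, on what has been measured and on what is new or still open speak of the compounds shown alone.

Three urea compounds share one core and differ only in where chlorine sits on one ring. Compound 1, `C[C@H](NC(=O)Nc1ccccc1Cl)c1ccccc1`, carries a single chloro group; in an ADME assay on the whole organism with Oryza sativa as the target, tested at 0.1 uM (on this read-out lower numbers stand for a stronger effect and higher numbers for a weaker effect at the one concentration tested), compound 1 gives 99%. Compound 3, `C[C@H](NC(=O)Nc1cccc(Cl)c1Cl)c1ccccc1`, is made from compound 1 by chloro in place of hydrogen on an aromatic carbon, and in this assay compound 3 gives 100%, so the step of a number 1 percentage points higher from compound 1 to compound 3 (within the scatter) is small. Compound 2, `C[C@@H](NC(=O)Nc1cccc(Cl)c1)c1ccccc1`, is built from the same atoms as compound 1 joined differently; the difference between the two cores is not broken down here. In this assay compound 2 gives 97%, which sits within the scatter of both compound 1 and compound 3, so none of the three can be called stronger or weaker than another.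

Compound 4, `C[C@@H](NC(=O)Nc1cc(Cl)cc(Cl)c1)c1ccccc1`, is not yet measured. It arises from compound 2 by chloro in place of hydrogen on an aromatic carbon. This is the same kind of change as from compound 1 to compound 3, though not the same: there the incoming chloro group stood ortho to a chloro group, here it stands meta to a chloro group, and in both cases meta to a large group. Because the earlier step of a number 1 percentage points higher from compound 1 to compound 3 (within the scatter) left the read-out essentially unchanged, the step of a number 1 percentage points higher from compound 2 to compound 4 (within the scatter) is expected to be of a similar small size. For compound 4 in this assay the value is therefore estimated at 98%, with a likely range from 91% to 100%.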

Compound 4, a percentage reported as activity, at one concentration (the size of the read-out at that concentration, not a potency): 99%
Compound 4: the middle estimate sits 1 percentage points below what was measured; the range from low to high includes it.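

In this assay, the added chloro group gives a small step, a number 2 percentage points higher from compound 2 to compound 4 (within the scatter). Set beside the same change on the core of compound 1, the two steps do not differ, so in these two pairs the change carries over from one core to the other and leaves the read-out essentially where it was: the same change on two cores in this assay, a number 1 percentage points higher (within the scatter) from compound 1 to compound 3 and a number 2 percentage points higher (within the scatter) from compound 2 to compound 4, 1 percentage points apart, within the scatter of two such steps. This agreement is only between two steps that are both within the scatter, so it shows that the change had no clear effect on either core, not that a measurable effect would carry over; with just two pairs, in which the incoming chloro group does not stand in the same place, it also gives no rule for the wider series.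

The compounds shown carry only chloro groups or hydrogen on the substituted ring, so it remains open whether a different group there, such as an amine, a carboxylic acid or a longer chain, would move the read-out beyond the scatter. Going by these compounds, it is also open how these compounds would behave at other concentrations, as a reading at a single concentration is not a measure of potency.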